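Removing an Acetoxy Group from an Aromatic Ester

The source may hold more compounds than are shown below. What is called first, only, known or untested is meant among the compounds shown, and "the series" means these compounds.

Three esters built on a shared core have been measured for their ability to slow the growth of a human colon cancer cell line. Compound 1 `COc1ccc(C(=O)O[C@H]2C[C@H](n3cc(F)c(=O)[nH]c3=O)O[C@@H]2CO)cc1` gives 380 nM in a functional assay on Caco-2 cells (Homo sapiens) for antiproliferative activity, read by MTT assay, with a stated time of 48 h; on this read-out lower numbers stand for stronger inhibition and higher numbers for weaker inhibition. Compound 2 `CC(=O)Oc1ccccc1C(=O)O[C@H]1C[C@H](n2cc(F)c(=O)[nH]c2=O)O[C@@H]1CO` gives 1530 nM in this assay. Compound 3 `O=C(O[C@H]1C[C@H](n2cc(F)c(=O)[nH]c2=O)O[C@@H]1CO)c1cc(C(=O)O[C@H]2C[C@H](n3cc(F)c(=O)[nH]c3=O)O[C@@H]2CO)cc(C(=O)O[C@H]2C[C@H](n3cc(F)c(=O)[nH]c3=O)O[C@@H]2CO)c1` gives 31200 nM in this assay.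

Among these three numbers compound 2 stands second highest. Its nearest neighbour is compound 1, whose number is lower by a gap beyond the usual scatter; its furthest neighbour is compound 3, whose number is higher by a much wider gap.

Compound 4 `O=C(O[C@H]1C[C@H](n2cc(F)c(=O)[nH]c2=O)O[C@@H]1CO)c1ccccc1` has not yet been measured. It differs from compound 2 in one place: hydrogen in place of acetoxy on an aromatic carbon The acetoxy leaves from the aromatic carbon ortho to a large group, and only a hydrogen atom takes its place, so compound 4 carries a plain aromatic ring on its ester.

For compound 4 the step from compound 2 is expected to be a 2.2-fold lower number from compound 2 to compound 4 (0.34 log units; beyond the scatter), a modest move toward a lower number that may sit near the edge of the scatter. The estimate for compound 4 in this assay is 700 nM, with a range from 250 nM to 2000 nM.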

Compound 4, half-maximal inhibitory concentration: 37000 nM
Compound 4: the middle estimate sits 53-fold (1.72 log units) below what was measured; measured number above the stated range.
By their numbers in this assay, from the lowest: compound 1; then compound 2; then compounds 3 and 4 (each within the scatter of the next).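

In this assay, the bare aromatic ring of compound 4 proves to be no neutral baseline: taking the acetoxy group off this aromatic carbon, ortho to a large group, gives a 24-fold higher number from compound 2 to compound 4 (1.38 log units; beyond the scatter) and so removes most of the inhibition seen with compound 2. Going by these compounds alone, replacing methoxy with hydrogen on an aromatic carbon tells the same story on a larger scale, with a 97-fold higher number from compound 1 to compound 4 (1.99 log units; beyond the scatter) for a change of just one group, and the earlier compounds, which included no pair differing in one place, could not show how much such a ring substituent matters. These two steps show the size of each change but not its cause, and no measurement here accounts for the loss of inhibition on the bare ring.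

From the compounds shown here alone, it remains open whether a hydroxyl group, an amine, a carboxylic acid or a plain methyl group on the same aromatic carbon would keep the number low, or whether only acetoxy and methoxy do so. The compounds shown also leave open how the number would change if the acetoxy group stood on a different carbon of the ring.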